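Inverting One Stereocentre in a Propyl-Bearing Pair

The compounds below may be only part of what the source reports. "The series", "measured", "known", "first", "only" and "open" are said of these compounds alone.

Of the compounds shown here, two have so far been measured in a physicochemical assay for lipophilicity, using the shake flask method, in phosphate buffer, measured as octanol-water partition, at pH 7.4; a lower number here means a more polar compound, a higher number a more lipophilic compound. Compound 1 `Cc1cn([C@H]2CCCN(Cc3ccc(C(=O)O)c(Oc4cccc(Cl)c4)c3F)C2)c(=O)[nH]c1=O` gives -0.59, and compound 2 `CCC[C@@H](c1ccc(C(=O)O)c(Oc2cccc(Cl)c2)c1F)N1CCC[C@H](n2cc(C)c(=O)[nH]c2=O)C1` gives 0.51, the higher of the two numbers. Among the measured compounds shown here, the single measured step, a number 1.10 log units higher from compound 1 to compound 2 (beyond the scatter), is large and came with propyl in place of hydrogen on a saturated chain carbon bound to an amine nitrogen in a ring and an aromatic carbon.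

Compound 3 `CCC[C@H](c1ccc(C(=O)O)c(Oc2cccc(Cl)c2)c1F)N1CCC[C@H](n2cc(C)c(=O)[nH]c2=O)C1` is the next to be measured, and its relation to compound 2 is narrow: the two compounds have the same atoms and bonds and differ only in configuration as drawn: 1 of 2 stereo elements differ; a stereocentre at a saturated chain carbon is drawn S in compound 2 and R in compound 3. A stereocentre at a saturated chain carbon is drawn S in compound 2 and R in compound 3. For the measured compounds named here, the step to compound 2, a number 1.10 log units higher from compound 1 to compound 2 (beyond the scatter), reports the arrival of the propyl and says nothing about its configuration, and no measured pair differs in configuration alone. Going by the values given here, the only guide is therefore the value of compound 2, 0.51, and no change beyond the scatter is expected. The expected step, a number 0.01 log units lower from compound 2 to compound 3 (within the scatter), is estimated to be negligible. For compound 3 the estimated value is 0.5, with an expected range from 0.15 to 0.85.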

Compound 3, distribution coefficient: 0.53
Compound 3: the middle estimate sits 0.03 log units below what was measured; the measured number falls inside the stated range.
By their numbers in this assay, from the lowest: compound 1; then compounds 2 and 3 (each within the scatter of the next).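

Among the compounds shown here, this pair is the first to isolate configuration at the saturated chain carbon that carries the propyl, and in this assay inverting it gives a number 0.02 log units higher from compound 2 to compound 3 (within the scatter), so the two drawn arrangements cannot be told apart by this measurement. The earlier propyl step therefore does not depend on which configuration is drawn at this carbon: a number 1.12 log units higher from compound 1 to compound 3 (beyond the scatter), which is large, as is a number 1.10 log units higher from compound 1 to compound 2 (beyond the scatter). The comparison between the two propyl-bearing compounds concerns this single stereocentre and no other part of the structure: the fact that compounds 2 and 3 differ only in the configuration as drawn

The compounds shown leave open whether the same holds at this carbon for other substituents, such as a methyl group, a longer chain, or a chain ending in an amine or a carboxylic acid. They also leave open what inverting the second stereocentre would do, since it is drawn the same way in compound 2 and compound 3, and whether configuration at the propyl-bearing carbon matters in any measurement other than this partition read-out.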